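The source may report more compounds than this note shows. Statements on the series, on what has been measured and on what is new or still open speak of the compounds shown alone.

Among the compounds with values here, in a functional assay on CCRF-CEM cells (Homo sapiens) (on this read-out lower numbers stand for stronger inhibition and higher numbers for weaker inhibition), three compounds have numbers so far. Compound 1 `Cc1ccc(/C=C/C(=O)Oc2ccc(/C=C3\CCCCC3=O)cc2)cc1` gives 230000 nM, compound 2 `O=C1CCCC/C1=C\c1ccc(OC(=O)c2ccc(Cl)cc2)cc1` gives 41000 nM, and compound 3 `COc1ccc(C(=O)Oc2ccc(/C=C3\CCCC(CN(C)C)C3=O)cc2)cc1` gives 5070 nM. Compound 2 therefore stands in the middle, with the second highest number of the three, and its gaps to compound 1 and compound 3 both lie beyond the scatter. No two of these compounds differ in one place only, so this assay offers no direct measure of a single change.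

Compound 4 `O=C(CCc1ccccc1)Oc1ccc(/C=C2\CCCCC2=O)cc1` departs from compound 2 in one place: phenethyl in place of 4-chlorophenyl on a carbonyl carbon. Compound 3 also differs in the shared core, which makes it a weaker guide here. The expectation rests instead on compound 2 at 41000 nM and compound 1 at 230000 nM, and a value between those two seems likely. The step expected is a 2.2-fold higher number from compound 2 to compound 4 (0.34 log units; beyond the scatter), a modest rise toward weaker inhibition. For compound 4 the estimated value is 90000 nM, with an expected range of 25000 nM to 300000 nM.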

Compound 4, half-maximal inhibitory concentration: 34400 nM
Compound 4: the middle estimate sits 2.6-fold (0.42 log units) above what was measured; low and high end bracket the measured number.
By their numbers in this assay, from the lowest: compound 3; then compounds 4 and 2 (each within the scatter of the next); then compound 1.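

In this assay, the first direct measure of a single change in this series shows a 1.2-fold lower number from compound 2 to compound 4 (0.08 log units; within the scatter) when phenethyl stands in place of 4-chlorophenyl on a carbonyl carbon. At this place, the read-out does not separate the two groups, so this pair gives no sign that the number depends on which of them is present. The chlorine leaves and a six-membered aromatic ring of carbon only remains, now carried by phenethyl, and the two compounds still cannot be told apart.

On these data alone, whether an amine, a carboxylic acid or a longer chain at this place would shift the number remains open, as does whether the same exchange would hold on the core of compound 3. No measurement offered here accounts for the result.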